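A Chloro Group on the Propyl Chain of Compound 3

The compounds below may be only part of what the source reports. "The series", "measured", "known", "first", "only" and "open" are said of these compounds alone.

In a functional assay on IMR-32 cells (Homo sapiens) for antiproliferative activity, read by sulforhodamine B assay, with a stated time of 48 h (a lower number here means a stronger inhibitor of growth, a higher number a weaker inhibitor of growth), compound 1 `COc1ccc(-c2cn(CCCN3C(=O)COc4ccccc43)nn2)cc1` gives 49900 nM, compound 2 `O=C1COc2ccccc2N1CCCn1cc(-c2ccccn2)nn1` gives 2000 nM and compound 3 `CCCc1cn(CCCN2C(=O)COc3ccccc32)nn1` gives 1400 nM. Compound 3 thus stands within the scatter of compound 2, as a 1.4-fold lower number from compound 2 to compound 3 (0.15 log units; within the scatter) shows, and well apart from compound 1, as a 36-fold lower number from compound 1 to compound 3 (1.55 log units; beyond the scatter) shows. Replacing 4-methoxyphenyl with pyridin-2-yl also gave a large change, a 25-fold lower number from compound 1 to compound 2 (1.40 log units; beyond the scatter).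

Compound 4 `O=C1COc2ccccc2N1CCCn1cc(CCCCl)nn1` differs from compound 3 by a single change, (chloro in place of hydrogen on a saturated chain carbon, three bonds along the chain from an aromatic carbon), which turns propyl into 3-chloropropyl. Among the measured compounds shown here, no measured step alters the end of such a chain, so the evidence is indirect. Both large steps start from the 4-methoxyphenyl of compound 1, whereas exchanging pyridin-2-yl for propyl gave only a 1.4-fold lower number from compound 2 to compound 3 (0.15 log units; within the scatter). No shift beyond the scatter is therefore expected in this assay. The expected change is a 1.1-fold higher number from compound 3 to compound 4 (0.06 log units; within the scatter). Compound 4 is estimated at 1600 nM, with an expected range from 550 nM to 5000 nM.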

Compound 4, concentration for 50% growth inhibition: 200 nM
Compound 4: middle estimate off by 8.0-fold (0.90 log units), on the high side, outside the stated range (below it).
By their numbers in this assay, from the lowest: compound 4; then compounds 3 and 2 (each within the scatter of the next); then compound 1.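

In this assay the end of the propyl chain proves sensitive to a single atom: chloro in place of hydrogen, three bonds along the chain from an aromatic carbon, gives a 7.0-fold lower number from compound 3 to compound 4 (0.85 log units; beyond the scatter) even though the earlier exchange of pyridin-2-yl for propyl stayed within the scatter. Among the compounds shown here, the 3-chloropropyl group also stands apart from both other groups on that aromatic carbon, with a 10-fold lower number from compound 2 to compound 4 (1.00 log units; beyond the scatter) for pyridin-2-yl and a 250-fold lower number from compound 1 to compound 4 (2.40 log units; beyond the scatter) for 4-methoxyphenyl, whereas the earlier compounds set only 4-methoxyphenyl apart. Nothing shown here bears on the reason for this step.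

The compounds shown leave open whether the step belongs to chloro itself or would also follow from a bromo, hydroxyl or amino group at the chain end. They also leave open whether the chloro group would give a similar step on a shorter 2-chloroethyl chain or a longer 4-chlorobutyl chain.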